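A few compounds are considered here, and "the series" means these few. Any claim that something is new, unique, unknown or untested is made for them only; others in the source may bear on it.

Working notes on the series.

Compound 1 `O=C(CSc1nc(Nc2ccccc2)c2ccccc2n1)Nc1cccc(Cl)c1` is the point of reference. In a functional assay on NCI-H1975 cells (Homo sapiens) for inhibition, read by MTT assay, with a stated time of 72 h (on this read-out higher numbers stand for weaker inhibition and lower numbers for stronger inhibition), compound 1 gives 8460 nM. Compound 3 `O=C(CSc1nc(Nc2ccccc2)c2ccccc2n1)Nc1ccc(F)c(Cl)c1` differs from compound 1 by fluoro in place of hydrogen on an aromatic carbon. In this assay compound 3 gives 9390 nM, and the step is a 1.1-fold higher number from compound 1 to compound 3 (0.05 log units; within the scatter). Compound 2 `C=CC(=O)Nc1cccc(NC(=O)CSc2nc(Nc3ccccc3)c3ccccc3n2)c1` has a different core: the cores of compound 1 and compound 2 differ by (vinylcarbonyl)amino in place of chloro on an aromatic carbon. In this assay compound 2 gives 8120 nM, a step of a 1.0-fold lower number from compound 1 to compound 2 (0.02 log units; within the scatter). Between compound 2 and compound 3 the step is a 1.2-fold higher number from compound 2 to compound 3 (0.06 log units; within the scatter). All three values sit within the scatter of one another, so no ranking is drawn among them.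

Compound 4 `C=CC(=O)Nc1cccc(NC(=O)CSc2nc(Nc3ccccc3F)c3ccccc3n2)c1` has not yet been measured. Against compound 2 it shows (fluoro in place of hydrogen on an aromatic carbon). Within the data shown here, this is the same kind of change as the one from compound 1 to compound 3, not the same change: in compound 3 the entering fluoro sits ortho to a chloro group and para to a large group, whereas in compound 4 it sits ortho to a large group, and the cores of the two pairs differ as told above. Among the measured compounds shown here, the only measured instance of this kind of change, from compound 1 to compound 3, moved the number by a 1.1-fold higher number from compound 1 to compound 3 (0.05 log units; within the scatter), within the scatter. Resting on that step, the step from compound 2 to compound 4 is expected to be about a 1.0-fold higher number from compound 2 to compound 4 (0.02 log units; within the scatter). Compound 4 is accordingly estimated at 8500 nM in this assay, with the expected range running from 4000 nM to 18000 nM.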

Compound 4, half-maximal inhibitory concentration: 6580 nM
The estimate for compound 4 lay 1.3-fold (0.11 log units) above the measured number; the measured number falls inside the stated range.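

In this assay, fluoro in place of hydrogen on an aromatic carbon, here ortho to a large group, amounts to a 1.2-fold lower number from compound 2 to compound 4 (0.09 log units; within the scatter), so this step stays inside the usual variation of the read-out. Set beside the only other instance of this kind of change, the step on the second core does not differ from the first beyond what repeat measurement allows: the same change on two cores in this assay, a 1.1-fold higher number (0.05 log units; within the scatter) from compound 1 to compound 3 and a 1.2-fold lower number (0.09 log units; within the scatter) from compound 2 to compound 4, 1.4-fold (0.14 log units) apart, within the scatter of two such steps. This shows that on both cores the change leaves the number within the scatter, but it does not show that a fluoro effect carries from one core to another, as neither step is large enough to be read as an effect, the fluoro stands at a different place in the two pairs, and two pairs are a narrow base.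

The compounds shown leave open whether any substituent on the anilino ring can move the number beyond the scatter, for example a methoxy group, an amine or a carboxylic acid in place of the fluoro of the 2-fluorophenyl group. They also leave open whether a longer chain between the sulfur and the amide carbonyl would change the number on either core.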